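Stereochemistry at the indanol core and receptor binding

The source may report more compounds than this note shows. Statements on the series, on what has been measured and on what is new or still open speak of the compounds shown alone.

Measured compounds: compound 1 `O[C@H]1Cc2ccccc2C1NC1CCN(CCCc2c[nH]c3ccc(-n4cnnc4)cc23)CC1` gives 37 nM; compound 2 `OC[C@H](NC1CCN(CCCc2c[nH]c3ccc(-n4ccnc4)cc23)CC1)c1ccccc1` gives 0.7 nM.

In an assay on CHO cells for displacement of a labelled ligand from 5-hydroxytryptamine receptor 1D (Homo sapiens) (a higher number here means a weaker inhibitor, a lower number a stronger inhibitor), compound 1 stands highest of the two numbers shown, and compound 2 lies well beyond the scatter below it. Compound 3 `O[C@@H]1Cc2ccccc2[C@H]1NC1CCN(CCCc2c[nH]c3ccc(-n4cnnc4)cc23)CC1` is the unmeasured partner of compound 1: the two compounds have the same atoms and bonds; at least one stereo element is drawn with a configuration in one of them and without one in the other: 2 of 2 stereo elements differ; a stereocentre at a saturated ring carbon is drawn S in compound 1 and R in compound 3; a stereocentre at a saturated ring carbon is drawn without a configuration in compound 1 and R in compound 3. Within the data shown here, no measured pair shows what fixing these two stereocentres does here, so the account can only expect a change of modest size in either direction, or none beyond the scatter. Compound 3 is estimated at 20 nM, within 5 nM to 150 nM, an expected step of a 1.9-fold lower number from compound 1 to compound 3 (0.27 log units; within the scatter).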

Compound 3, half-maximal inhibitory concentration: 6.6 nM
Compound 3: middle estimate off by 3.0-fold (0.48 log units), on the high side; the measured number falls inside the stated range.
By their numbers in this assay, from the lowest: compound 2; then compound 3; then compound 1.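

Among these compounds, since compound 1 and compound 3 share the same atoms and bonds, a 5.6-fold lower number from compound 1 to compound 3 (0.75 log units; beyond the scatter) in this assay is the first evidence that the way the two saturated ring carbons are drawn matters at this core. The earlier compounds shown here differ in more than one place and could not show this. The step is not a clean comparison of two fully defined forms, and it should be read with this in mind: the fact that one of compounds 1 and 3 is drawn with a defined configuration and the other without, at the place where they differ.

As far as these compounds go, how much of the step belongs to each stereocentre remains open. So does whether the same preference would hold if an amine replaced the hydroxyl group on the core.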